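From 4-methoxyphenyl to naphthalen-1-yl on the sulfonyl sulfur

The compounds below may be only part of what the source reports. "The series", "measured", "known", "first", "only" and "open" are said of these compounds alone.

Compound 1 `O=C(/C=C/c1cn(S(=O)(=O)c2ccc([N+](=O)[O-])cc2)c2ccccc12)c1ccncc1`: > 150000 nM
Compound 2 `O=C(/C=C/c1cn(S(=O)(=O)c2cccc([N+](=O)[O-])c2)c2ccccc12)c1ccncc1`: > 150000 nM
Compound 3 `COc1ccc(S(=O)(=O)n2cc(/C=C/C(=O)c3ccncc3)c3ccccc32)cc1`: > 150000 nM

In an ADME assay on HEK293 cells (Homo sapiens) for antiproliferative activity, read by MTT assay, with a stated time of 48 h (on this read-out lower numbers stand for stronger inhibition and higher numbers for weaker inhibition), compound 3 gives > 150000 nM, which is a limit and not a number. It has no readable place in the series, since all three compounds share one reading: the limit of > 150000 nM in this assay, at which 3 of the 3 values shown sit.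

Compound 4 `O=C(/C=C/c1cn(S(=O)(=O)c2cccc3ccccc23)c2ccccc12)c1ccncc1` keeps the shared core and changes only the group on the sulfonyl sulfur: naphthalen-1-yl in place of 4-methoxyphenyl on a sulfonyl sulfur.

Three measured steps alter that same group: a step that the two limits leave unreadable from compound 1 to compound 2, a step that the two limits leave unreadable from compound 1 to compound 3 and a step that the two limits leave unreadable from compound 2 to compound 3. None of them has a size that can be read, so they offer no measured size or direction to carry over. A step beyond the scatter is therefore not expected in this assay, in either direction. The expected step is a step that the limit leaves unreadable from compound 3 to compound 4. For compound 4 the estimate is 180000 nM, with an expected range from 80000 nM to 400000 nM. The assay may well report only a limit again.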

Compound 4, half-maximal inhibitory concentration: > 150000 nM
Compound 4: only a limit was reported; the forecaster's own chance of this, stated with the estimate: 80%; the middle value is on the limit's open side.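

In this assay, for the compounds shown here, compound 4 gives > 150000 nM, which is a limit and not a number, so no step linking it to compound 1, compound 2 or compound 3 can be read. The compounds shown leave open how these groups on the sulfonyl sulfur rank, since all share one reading: the limit of > 150000 nM in this assay, at which 4 of the 4 values shown sit.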